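The source may hold more compounds than are shown below. What is called first, only, known or untested is meant among the compounds shown, and "the series" means these compounds.

Compound 1 `COc1ccc(C(=O)c2cc(OC)c(OC)c(OC)c2)cc1N` is the smallest member of the group, an aniline bearing the shared core. In a functional assay on DU-145 cells (Homo sapiens) for cytotoxicity, read by MTT assay, with a stated time of 72 h (on this read-out higher numbers stand for weaker inhibition and lower numbers for stronger inhibition), compound 1 gives 2100 nM. Compound 2 `COc1ccc(C(=O)c2cc(OC)c(OC)c(OC)c2)cc1NC(=O)/C=C/c1ccc(F)cc1` carries on the same nitrogen a (2-(4-fluorophenyl)ethenyl)carbonyl group, and in this assay compound 2 gives 3900 nM. The change from compound 2 to compound 1 is hydrogen in place of (2-(4-fluorophenyl)ethenyl)carbonyl on a nitrogen on an aromatic ring, and it made a step of a 1.9-fold lower number from compound 2 to compound 1 (0.27 log units; within the scatter).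

Compound 3 `COc1cc(C(=O)c2cc(OC)c(OC)c(OC)c2)cc(NC(=O)/C=C/c2ccc(F)cc2)c1OC` differs from compound 2 in its core: methoxy in place of hydrogen on an aromatic carbon. In this assay compound 3 gives 6700 nM, a step of a 1.7-fold higher number from compound 2 to compound 3 (0.24 log units; within the scatter), so the two cores sit close to one another on this read-out.

Compound 4 `COc1cc(C(=O)c2cc(OC)c(OC)c(OC)c2)cc(N)c1OC` stands to compound 3 as compound 1 stands to compound 2. The difference is hydrogen in place of (2-(4-fluorophenyl)ethenyl)carbonyl on a nitrogen on an aromatic ring; the place is described in the same words for both pairs, so this is the same change, carried out on the core of compound 3 rather than that of compound 2. Among the compounds with values here, nothing is known about how the cinnamamide-bearing compounds and the free anilines differ in mechanism, so the expectation rests only on the one measured pair. Because the earlier step was a 1.9-fold lower number from compound 2 to compound 1 (0.27 log units; within the scatter), the step from compound 3 to compound 4 is expected to be of similar size, estimated as a 1.9-fold lower number from compound 3 to compound 4 (0.27 log units; within the scatter). Compound 4 is therefore estimated to give 3600 nM in this assay, with a plausible span from 1500 nM to 9000 nM.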

Compound 4, half-maximal inhibitory concentration: 10000 nM
The estimate for compound 4 lay 2.8-fold (0.44 log units) below the measured number, outside the stated range (above it).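

In this assay, taking the (2-(4-fluorophenyl)ethenyl)carbonyl group off the nitrogen of compound 3 gave a 1.5-fold higher number from compound 3 to compound 4 (0.17 log units; within the scatter), while the methoxy in place of hydrogen on an aromatic carbon, compared on the two free anilines, gave a 4.8-fold higher number from compound 1 to compound 4 (0.68 log units; beyond the scatter). The loss of the (2-(4-fluorophenyl)ethenyl)carbonyl group therefore did not carry over as a fixed step from the core of compound 2 to the core of compound 3, and the two steps stand further apart than the scatter allows: the same change on two cores in this assay, a 1.9-fold lower number (0.27 log units; within the scatter) from compound 2 to compound 1 and a 1.5-fold higher number (0.17 log units; within the scatter) from compound 3 to compound 4, 2.8-fold (0.44 log units) apart, beyond the scatter of two such steps Each of those two steps lies within the scatter on its own, so the four compounds show that the change depends on the core but do not establish a reversal of direction or give a rule for any further core, and the methoxy change, read on the same four compounds, gives the same picture: the same change on two cores in this assay, a 1.7-fold higher number (0.24 log units; within the scatter) from compound 2 to compound 3 and a 4.8-fold higher number (0.68 log units; beyond the scatter) from compound 1 to compound 4, 2.8-fold (0.44 log units) apart, beyond the scatter of two such steps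

The data do not say why the two cores respond differently, and four compounds on two cores cannot separate a real dependence from a chance combination of modest steps. Going by these compounds, it remains open how the free aniline and its amide would compare on either core with a smaller acyl group such as acetyl, or with a hydroxy group or a chlorine in place of the added methoxy.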